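Trimming a Heterocyclic Appendage on a Weak Cytotoxic Series

The compounds below may be only part of what the source reports. "The series", "measured", "known", "first", "only" and "open" are said of these compounds alone.

Three compounds were tested in a functional assay on MCF7 cells (Homo sapiens) for cytotoxicity, read by sulforhodamine B assay, with a stated time of 48 h; a lower number here means a stronger inhibitor, a higher number a weaker inhibitor. Compound 1 `SC1=NNCC(n2c(-c3ccco3)nc3ccccc32)=N1` gives 60500 nM, the highest of the three numbers. Compound 2 `NNC(=O)CSc1nnc(Cn2c(-c3ccco3)nc3ccccc32)s1` gives 21400 nM and compound 3 `Cc1ccc(-c2nc3ccccc3n2CC(=O)N/N=C/c2ccccc2Cl)o1` gives 21300 nM; each lies beyond the scatter below compound 1, and the two stand within the scatter of one another. Compound 4 `N#CCn1c(-c2ccco2)nc2ccccc21` has not yet been measured in this assay. It differs from compound 1 by a group of 3 heavy atoms (2 carbon, 1 nitrogen; no ring) in place of a group of 7 heavy atoms (3 carbon, 3 nitrogen, 1 sulfur; one six-membered non-aromatic ring with 3 hetero atoms), on an aromatic nitrogen, so the group that leaves is much larger than the cyanomethyl that enters. Among the measured compounds shown here, no measured pair shows what such a change does here. With compound 1 at 60500 nM, compound 4 is expected to change little, the estimated step of a 1.1-fold lower number from compound 1 to compound 4 (0.04 log units; within the scatter) lying within the scatter in either direction; its expected value is 55000 nM, in a range from 18000 nM to 170000 nM.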

Compound 4, half-maximal inhibitory concentration: 88100 nM
For compound 4 the middle estimate is 1.6-fold (0.20 log units) below the measured one; the range from low to high includes it.
By their numbers in this assay, from the lowest: compounds 3 and 2 (each within the scatter of the next); then compounds 1 and 4 (each within the scatter of the next).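

In this assay, cyanomethyl in place of the much larger ring-bearing group on the aromatic nitrogen gives a 1.5-fold higher number from compound 1 to compound 4 (0.16 log units; within the scatter). Among the compounds shown here, this is the first measured change at this position, and it shows that the six-membered non-aromatic ring and its sulfur can be exchanged for a far smaller group without a change beyond the scatter. Nothing available explains this result.

Still open, on these data alone, is whether any group on this nitrogen moves the number beyond the scatter. An acetic acid chain or a simple aminoethyl chain there would test this.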